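Swapping the Aryl Group on the Piperazine of Compound 3

A few compounds are considered here, and "the series" means these few. Any claim that something is new, unique, unknown or untested is made for them only; others in the source may bear on it.

Of the compounds shown here, three share one core and have been tested in an assay on BT-474 cells for inhibition of disintegrin and metalloproteinase domain-containing protein 10 (Homo sapiens); on this read-out lower numbers stand for stronger inhibition and higher numbers for weaker inhibition. Compound 1 `Cc1cccc(C2=CCN(C(=O)[C@H]3NCC4(CC4)C[C@@H]3C(=O)NO)CC2)c1` gives 42 nM. Among the measured compounds shown here, compound 2 `CCc1cccc(C2=CCN(C(=O)[C@H]3NCC4(CC4)C[C@@H]3C(=O)NO)CC2)c1` gives 240 nM, and the single change between them, a 5.7-fold higher number from compound 1 to compound 2 (0.76 log units; beyond the scatter), is the only one-step comparison available. Compound 3 `Cc1cc(N2CCN(C(=O)[C@H]3NCC4(CC4)C[C@@H]3C(=O)NO)CC2)ccc1C#N` gives 594 nM, the highest of the three numbers, standing beyond the scatter from both compound 2 and compound 1.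

Compound 4 `O=C(NO)[C@H]1CC2(CC2)CN[C@@H]1C(=O)N1CCN(c2cccc(Cl)c2)CC1` has not yet been measured. It differs from compound 3 in one place: 3-chlorophenyl in place of 4-cyano-3-methylphenyl on an amine nitrogen in a ring. For the measured compounds named here, nothing measured so far bears directly on this change. Going by the values given here, the one known step concerns a methyl added to a chain carbon on a different kind of ring, and it does not involve the piperazine aryl group or any of the groups exchanged here. The two aryl-bearing compounds 1 and 2 carry a small group on the phenyl ring, as compound 4 does, and both sit below compound 3, but they also differ from compound 4 in the ring that links the aryl group to the core, so they offer only a loose hint.

On that basis the number for compound 4 is expected to land somewhat below compound 3, a step of a 2.0-fold lower number from compound 3 to compound 4 (0.30 log units; within the scatter), though the direction is uncertain. The estimate for compound 4 in this assay is 300 nM, with a range from 60 nM to 1500 nM.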

Compound 4, half-maximal inhibitory concentration: 42 nM
Estimate against measurement, compound 4: 7.1-fold (0.85 log units) above; the whole stated range lies above it.
By their numbers in this assay, from the lowest: compounds 1 and 4 (each within the scatter of the next); then compound 2; then compound 3.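

In this assay, the aryl group on the amine nitrogen in the ring proves to matter a great deal: 3-chlorophenyl in place of 4-cyano-3-methylphenyl gives a 14-fold lower number from compound 3 to compound 4 (1.15 log units; beyond the scatter), a large change from one exchange at a single position. Among the compounds shown here, this is the first one-step comparison at this position, and none of the earlier steps could show how much it can move the number. It also shows that the high number of compound 3 is not set by the shared core alone, since compound 4 keeps that core and gives 42 nM in this assay, with no measured evidence here to explain the step.

The compounds shown leave open which part of the exchange carries the step, since the nitrile and the methyl leave together while the chlorine enters. A plain phenyl, a 4-cyanophenyl or a 3-methylphenyl on the same nitrogen would help to separate these parts, and a 4-chlorophenyl would test whether the place of the chlorine on the ring matters.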